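The source may hold more compounds than are shown below. What is called first, only, known or untested is meant among the compounds shown, and "the series" means these compounds.

Compound 1 `OC(CCCN1CCN(c2ncc(F)cn2)CC1)C1CCCCC1` gives 12 nM in an assay (Cavia porcellus) for displacement of a labelled ligand from Sigma non-opioid intracellular receptor 1 (Homo sapiens) (on this read-out higher numbers stand for weaker inhibition and lower numbers for stronger inhibition), the lower of the two numbers reported here. Compound 3 `CC(=O)OC(CCCN1CCN(c2ncc(F)cn2)CC1)c1ccc(F)cc1` gives 227 nM in this assay, a number that lies beyond the scatter from that of compound 1. Compound 2 `OC(CCCN1CCN(c2ncc(F)cn2)CC1)(c1ccc(F)cc1)C1CCCCC1` gives no result reported in this assay. Compound 4 `Fc1ccc(SCCCN2CCN(c3ncc(F)cn3)CC2)cc1` differs from compound 1 in a single place: (4-fluorophenyl)sulfanyl in place of cyclohexyl(hydroxy)methyl on a saturated chain carbon, three bonds along the chain from an amine nitrogen in a ring. Among the compounds with values here, no step between two measured compounds mirrors this change, so the expectation rests on the structures alone. The step of a 3.3-fold higher number from compound 1 to compound 4 (0.52 log units; beyond the scatter) is expected to run toward weaker binding, possibly beyond the scatter. Compound 4 is therefore estimated at 40 nM, with a range from 8 nM to 200 nM.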

Compound 4, half-maximal inhibitory concentration: 51 nM
The estimate for compound 4 lay 1.3-fold (0.11 log units) below the measured number, and the stated range covers the measured number.
By their numbers in this assay, from the lowest: compound 1; then compound 4; then compound 3.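

In this assay, the swap gives a 4.3-fold higher number from compound 1 to compound 4 (0.63 log units; beyond the scatter): binding weakens, but compound 4 still keeps a modest step from compound 1 despite replacing the whole group at this chain position. The change swaps a non-aromatic ring for an aromatic one and loses the hydrogen-bond donor, so this single step cannot show which difference matters. Nothing measured here explains the step. From the compounds shown here alone, it remains open how a ketone or an ether oxygen at this place on the chain would compare, with either ring attached.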